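The source may report more compounds than this note shows. Statements on the series, on what has been measured and on what is new or still open speak of the compounds shown alone.

Compound 2 `COc1cc2c(Oc3ccc(NC(=O)c4nn(-c5ccccc5C)ccc4=O)c(F)c3)ccnc2cc1OCCCCCCC(=O)NO` gives 4390 nM in a functional assay on HCT-116 cells (Homo sapiens) for inhibition, read by MTT assay, with a stated time of 72 h (on this read-out higher numbers stand for weaker inhibition and lower numbers for stronger inhibition), the highest of the two numbers recorded. Compound 1 `COc1cc2c(Oc3ccc(NC(=O)c4nn(-c5ccccc5)cc(C)c4=O)cc3)ccnc2cc1OCCCCCCC(=O)NO` gives 150 nM in this assay, a lower number by a margin beyond the scatter, though it differs from compound 2 in several places at once. Compound 3 `COc1cc2c(Oc3ccc(NC(=O)c4nn(-c5ccccc5C)cc(C)c4=O)c(F)c3)ccnc2cc1OCCCCCCC(=O)NO` differs from compound 2 by methyl in place of hydrogen on an aromatic carbon. Within the data shown here, no single-change step between measured compounds is available, so the expected direction rests on compound 1, which carries that methyl and gives 150 nM. A moderate fall is expected, by a 2.9-fold lower number from compound 2 to compound 3 (0.47 log units; beyond the scatter). Compound 3 is estimated at 1500 nM, within a range of 400 nM to 5000 nM.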

Compound 3, half-maximal inhibitory concentration: 2300 nM
Compound 3: the middle estimate sits 1.5-fold (0.19 log units) below what was measured; the range from low to high includes it.
By their numbers in this assay, from the lowest: compound 1; then compounds 3 and 2 (each within the scatter of the next).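

In this assay, among these compounds, methyl in place of hydrogen on this aromatic carbon, two atoms from the ring nitrogen, gives a 1.9-fold lower number from compound 2 to compound 3 (0.28 log units; within the scatter), the first single-change reading at this position. The position therefore accepts this one added carbon with no change that can be told from the scatter. Nothing available accounts for this result. Going by these compounds, whether an ethyl group, a methoxy group or an amine at the same carbon would give a step beyond the scatter stays open. So does whether the methyl would give the same step in compounds with another group on the phenyl ring.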